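Swapping a hydroxyethyl chain for an oxolane ring

The source may hold more compounds than are shown below. What is called first, only, known or untested is meant among the compounds shown, and "the series" means these compounds.

Measured so far:
- compound 1 `COc1ccc(-c2c(-c3ccc(OC)cc3)n(Cc3ccccc3)c3ncn([C@H]4CC[C@H](OC)CC4)c(=N)c23)cc1`: > 1000 10^-6 cm/s in an ADME assay for permeability, using PAMPA, with a stated time of 30 min, at pH 7.4 (a higher number here means that the compound crosses the layer faster, a lower number that the compound crosses the layer more slowly), a limit of the assay rather than a number
- compound 2 `COc1ccc(-c2c(-c3ccc(OC)cc3)n(Cc3ccccc3)c3ncn(CCO)c(=N)c23)cc1`: > 1000 10^-6 cm/s in this assay, again a limit rather than a number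

Compound 2 therefore stands at the upper limit of this assay, and so does compound 1. The step that the two limits leave unreadable from compound 1 to compound 2 cannot be sized because the limit of > 1000 10^-6 cm/s in this assay, at which 2 of the 2 values shown sit, holds both values, so the exchange of the ring for the short chain on the aromatic nitrogen left no readable mark in this assay.

Compound 3 `COc1ccc(-c2c(-c3ccc(OC)cc3)n(Cc3ccccc3)c3ncn(CC4CCOC4)c(=N)c23)cc1` is the next case. Its change from compound 2 is oxolan-3-yl in place of hydroxymethyl on a saturated chain carbon bound to an aromatic nitrogen. Within the data shown here, no measured step bears directly on this change, and the only step available is itself unreadable. With compound 2 already at the limit, the expectation is that compound 3 stays there as well, and the estimated step that the limit leaves unreadable from compound 2 to compound 3 is none beyond the scatter. Compound 3 is thus estimated at 1200 10^-6 cm/s in this assay, within a range from 600 10^-6 cm/s to 2000 10^-6 cm/s, most likely reported again as a limit.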

Compound 3, apparent permeability: > 1000 10^-6 cm/s
Compound 3 was reported as a limit (the forecaster's own chance of this, stated with the estimate: 85%); the middle value does not contradict the limit.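

No step can be read among compound 1, compound 2 and compound 3, because all three stop at the same limit: the limit of > 1000 10^-6 cm/s in this assay, at which 3 of the 3 values shown sit. The compounds shown leave open how far apart these three really lie in this assay, and whether 2-hydroxyethyl and (oxolan-3-yl)methyl differ there at all.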